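Swapping the sulfonyl aryl group on a fluorinated bicyclic core

A few compounds are considered here, and "the series" means these few. Any claim that something is new, unique, unknown or untested is made for them only; others in the source may bear on it.

The series rests on two measured compounds. Compound 1 `COc1ccc(-c2c(S(=O)(=O)c3ccc(C)c(F)c3)cnc3c(F)cccc23)cc1` and compound 2 `N#Cc1cccc(S(=O)(=O)c2cnc3c(F)cccc3c2-c2cccc(F)c2)c1` share a core and a sulfonyl-linked aryl ring, but carry different aryl groups on the core and different groups on the sulfonyl sulfur. In an ADME assay on microsomes from liver (Homo sapiens) for metabolic stability, tested at 2.5 uM (on this read-out higher numbers stand for fast clearance and lower numbers for slow clearance), compound 1 gives 3.27 mL/min. In this assay compound 2 gives 0.34 mL/min, the lower of the two numbers, and its gap to compound 1 lies beyond the usual scatter. No single-change step connects them, so their two values stand side by side without a cause being assigned.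

Compound 3 `Cc1ccc(S(=O)(=O)c2cnc3c(F)cccc3c2-c2cccc(F)c2)cc1F` has not been measured in this assay. It differs from compound 2 in one place: 3-fluoro-4-methylphenyl in place of 3-cyanophenyl on a sulfonyl sulfur. Compound 3 thus carries the 3-fluoro-4-methylphenyl group also found in compound 1, while keeping the 3-fluorophenyl group of compound 2.

For compound 3 an upward step is expected, a 4.4-fold higher number from compound 2 to compound 3 (0.64 log units; beyond the scatter), because compound 1, which bears the same 3-fluoro-4-methylphenyl group on the sulfonyl sulfur, gives 3.27 mL/min. The estimate for compound 3 is 1.5 mL/min, within a range of 0.5 mL/min to 4 mL/min.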

Compound 3, intrinsic clearance in a liver preparation (reported as CLH), per the amount of preparation that the assay uses: 3.92 mL/min
Compound 3: the middle estimate sits 2.6-fold (0.42 log units) below what was measured, within the range that was stated.
By their numbers in this assay, from the lowest: compound 2; then compounds 1 and 3 (each within the scatter of the next).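

Among the compounds shown here, with compound 3 in hand, the difference at the sulfonyl sulfur can be read on its own for the first time: in this assay, 3-fluoro-4-methylphenyl in place of 3-cyanophenyl gives a 12-fold higher number from compound 2 to compound 3 (1.06 log units; beyond the scatter), a large step with the 3-fluorophenyl group held constant on the core. The change on the aromatic carbon, 3-fluorophenyl in place of 4-methoxyphenyl, gives a 1.2-fold higher number from compound 1 to compound 3 (0.08 log units; within the scatter), so with 3-fluoro-4-methylphenyl on the sulfur this change does not separate the two compounds, and the gap first seen between compound 1 and compound 2 follows the sulfonyl group in this set. Nothing available explains why the exchange at the sulfur has so large an effect on this read-out.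

The compounds shown do not tell whether the step follows the loss of the nitrile or the arrival of the fluorine and methyl groups, and a plain phenyl ring on the sulfur would bear on that question. From the compounds shown here alone, whether 3-cyanophenyl gives a similar step with 4-methoxyphenyl on the core, or whether a pyridine ring on the sulfur would behave like either aryl group, also stays open.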